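Replacing the hydroxyphenyl group of compound 2

A few compounds are considered here, and "the series" means these few. Any claim that something is new, unique, unknown or untested is made for them only; others in the source may bear on it.

In a functional assay on K562 cells (Homo sapiens) for antiproliferative activity, read by MTT assay, with a stated time of 24 h (a lower number here means a stronger inhibitor, a higher number a weaker inhibitor), compound 1 (`COc1ccc(/C=C/C(=O)c2ccc(OC)c3c2OC(C)(C)C=C3)cn1`) gives > 10000 nM, which is a limit and not a number. Compound 2 (`COc1ccc(C(=O)/C=C/c2cccc(O)c2)c2c1C=CC(C)(C)O2`) gives > 10000 nM, also a limit and not a number. Within the data shown here, compound 2 therefore has no numerical potency here, and the series so far stands at the limit of > 10000 nM in this assay, at which 2 of the 2 values shown sit.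

The next structure, compound 3 (`COc1ccc(C(=O)/C=C/c2cc(Cl)ccc2O)c2c1C=CC(C)(C)O2`), differs from compound 2 in one group: 5-chloro-2-hydroxyphenyl in place of 3-hydroxyphenyl on a double-bonded chain carbon bound to a double-bonded chain carbon. It has 5-chloro-2-hydroxyphenyl in place of 3-hydroxyphenyl on a double-bonded chain carbon bound to a double-bonded chain carbon.

Among the measured compounds shown here, only one measured step bears on this change, as it falls at the same place: a step that the two limits leave unreadable from compound 1 to compound 2. That step has no readable size, so it offers no magnitude or direction to carry over. For the measured compounds named here, no step of a particular size or direction is therefore expected in this assay, and the expectation is simply that compound 3 will remain close to the limit seen so far.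

The step expected from this estimate is a step that the limit leaves unreadable from compound 2 to compound 3. For compound 3, the estimated value is 12000 nM, with an expected range of 4000 nM to 40000 nM.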

Compound 3, half-maximal inhibitory concentration: 5510 nM
Compound 3: middle estimate off by 2.2-fold (0.34 log units), on the high side, within the range that was stated.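

In this assay, among these compounds, compound 3 is the first compound to give a number rather than a limit, and the change to 5-chloro-2-hydroxyphenyl on a double-bonded chain carbon bound to a double-bonded chain carbon gives an at least 1.8-fold lower number from compound 2 to compound 3 (0.25 log units; that floor lies within the scatter), a floor and not a measured size. The same group in place of 6-methoxypyridin-3-yl gives an at least 1.8-fold lower number from compound 1 to compound 3 (0.25 log units; that floor lies within the scatter), again only a floor, whereas the earlier step between the two limits cannot be read. This position can therefore yield a measurable value, but the floors do not establish a difference beyond the scatter, and the other compounds remain at a limit: the limit of > 10000 nM in this assay, at which 2 of the 3 values shown sit.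

Compound 3 differs from compound 2 in both its chlorine and the place of its hydroxy group, and no compound shown has one of these features without the other, so it remains open which of them goes with the measurable value. From the compounds shown here alone, it is also open how this assay would read with an amine or a carboxylic acid in place of the chlorine.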